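The compounds below may be only part of what the source reports. "The series", "measured", "known", "first", "only" and "open" are said of these compounds alone.

Measured so far in a functional assay on BCG823 cells (Homo sapiens) for inhibition, read by MTT assay, with a stated time of 72 h; on this read-out higher numbers stand for weaker inhibition and lower numbers for stronger inhibition:
compound 1 `CN(C(=O)NC(=O)c1ccc(F)c(F)c1)c1nc(C(F)(F)F)c(C(=O)N/N=C/c2ccc(C(F)(F)F)cc2)s1` gives 3.85 ug/mL
compound 2 `CN(C(=O)NC(=O)c1ccc(Cl)cc1Cl)c1nc(C(F)(F)F)c(C(=O)N/N=C/c2ccc(C(F)(F)F)cc2)s1` gives 3.08 ug/mL
compound 3 `CN(C(=O)NC(=O)c1ccc(F)c(F)c1)c1nc(C(F)(F)F)c(C(=O)N/N=C/c2cc(C(F)(F)F)cc(C(F)(F)F)c2)s1` gives 3.51 ug/mL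

Compound 4 `CN(C(=O)NC(=O)c1ccc(Cl)cc1Cl)c1nc(C(F)(F)F)c(C(=O)N/N=C/c2cc(C(F)(F)F)cc(C(F)(F)F)c2)s1` is not yet measured. From compound 1 to compound 2 the change is 2,4-dichlorophenyl in place of 3,4-difluorophenyl on a carbonyl carbon; in this assay it gave a 1.3-fold lower number from compound 1 to compound 2 (0.10 log units; within the scatter). Compound 3 differs from compound 1 in the core; that difference is not broken down here, and the values of compound 1 and compound 3 lie close together. Compound 4 carries the same change relative to compound 3, (2,4-dichlorophenyl in place of 3,4-difluorophenyl on a carbonyl carbon), at an identical place. For the measured compounds named here, the step expected from compound 3 to compound 4 in this assay is a 1.3-fold lower number from compound 3 to compound 4 (0.10 log units; within the scatter), resting on the single earlier instance a 1.3-fold lower number from compound 1 to compound 2 (0.10 log units; within the scatter), which was within the scatter, so no more than a small shift is expected. Compound 4 is accordingly estimated at 2.8 ug/mL in this assay, with a range from 1.5 ug/mL to 5.5 ug/mL.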

Compound 4, half-maximal inhibitory concentration: > 100 ug/mL
Compound 4 gave a limit, no number (the forecaster's own chance of this, stated with the estimate: 2%); middle value at least 35-fold (1.55 log units) from the limit.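

In this assay compound 4 gives > 100 ug/mL, which is a limit of the assay and not a number. The change to 2,4-dichlorophenyl from 3,4-difluorophenyl on a carbonyl carbon gives an at least 28-fold higher number from compound 3 to compound 4 (1.45 log units; beyond the scatter), so its outcome on the core of compound 1 does not carry over to the core of compound 3: the same change on two cores in this assay, a 1.3-fold lower number (0.10 log units; within the scatter) from compound 1 to compound 2 and an at least 28-fold higher number (1.45 log units; beyond the scatter) from compound 3 to compound 4, at least 35-fold (1.55 log units) apart, beyond the scatter of two such steps This shows that the outcome of this change differs between these two cores, but it rests on a single pair of steps and does not show which feature of the cores is responsible, nor the full size of the second step.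

On these data alone, it remains open whether a phenyl carrying a single chlorine or a methoxy group on the same carbonyl carbon would stay near compound 3 or fall to the limit seen for compound 4. Also open, as far as these compounds go, is whether any other core would behave like the core of compound 1 or like the core of compound 3.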